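The source may report more compounds than this note shows. Statements on the series, on what has been measured and on what is new or still open speak of the compounds shown alone.

The study covers two measured compounds and one that is still to be measured. Compound 1, with the structure `ClCC#CCSc1cnc2ccccc2c1Cl`, was tested in a functional assay on CCRF-CEM cells (Homo sapiens) for antiproliferative activity, with a stated time of 72 h (a higher number here means a weaker inhibitor, a lower number a stronger inhibitor), and compound 1 gives 3.7 ug/mL. Compound 2 has the structure `CCOC(=O)OCC#CCSc1c(SC)cnc2ccccc12`; in this assay compound 2 gives 13.2 ug/mL. Of the two numbers recorded, compound 2 stands highest, and its nearest neighbour is compound 1, whose lower number sets it apart from compound 2 by more than the usual scatter of repeated measurements.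

The next compound, compound 3, has the structure `CSc1cnc2ccccc2c1SCC#CCOC(=O)c1ccccc1` and has not yet been measured. It differs from compound 2 in one place: phenyl in place of ethoxy on a carbonyl carbon. Within the data shown here, no pair of measured compounds shows a step of this kind, so there is nothing in the numbers so far to calibrate it against. Because compound 2 gives 13.2 ug/mL, the author expects the step of a 1.5-fold lower number from compound 2 to compound 3 (0.17 log units; within the scatter) in this assay to be modest, if anything toward a lower number, and not clearly beyond the scatter. The estimate for compound 3 in this assay is 9 ug/mL, with a range from 3.5 ug/mL to 25 ug/mL.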

Compound 3, concentration for 50% inhibition: 22.2 ug/mL
Compound 3: the middle estimate sits 2.5-fold (0.39 log units) below what was measured, within the range that was stated.
By their numbers in this assay, from the lowest: compound 1; then compounds 2 and 3 (each within the scatter of the next).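

In this assay, among these compounds, the exchange of ethoxy for phenyl on a carbonyl carbon, which turns ethoxycarbonyl into benzoyl, amounts to a 1.7-fold higher number from compound 2 to compound 3 (0.23 log units; within the scatter) and gives the first reading of this position. The two groups are not told apart here: a six-membered aromatic ring of carbon only can take the place of the open ethoxy group with no difference that stands clear of repeated measurement. Among the compounds shown here, nothing measured so far gives a reason for this outcome or says what either group does in the cells.

The compounds shown leave open whether a different group on that carbonyl carbon, such as an amine or a longer alkoxy chain, would give a number beyond the scatter from compound 2. They also leave open whether the exchange of ethoxy for phenyl would read the same with other groups elsewhere on the shared core.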